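This account rests on a few compounds, and the source may have more. Where it says the series, first, only, none or still open, it means among the compounds named here.

Working notes on the series. Compound 1 `CCOC(=O)c1cc(=O)c2cc(CSC(=S)N(C(C)C)C(C)C)ccc2o1` in a functional assay on HEp-2 cells (Homo sapiens) for antiproliferative activity, read by MTT assay, with a stated time of 72 h (a higher number here means a weaker inhibitor, a lower number a stronger inhibitor), gives 15900 nM. Compound 2 `CC(C)N(C(=S)SCc1oc2ccccc2c(=O)c1Cl)C(C)C` gives 20000 nM in this assay; the two numbers lie within the usual scatter of each other, and the difference between the two cores is not broken down here. Compound 3 `O=c1c(Cl)c(CSC(=S)N2CCCC2)oc2ccccc12` gives 600 nM in this assay. The change from compound 2 to compound 3 is pyrrolidin-1-yl in place of diisopropylamino on a thiocarbonyl carbon and it made a large step, a 33-fold lower number from compound 2 to compound 3 (1.52 log units; beyond the scatter). Compound 4 `CCOC(=O)c1cc(=O)c2cc(CSC(=S)N3CCCC3)ccc2o1` carries the same change on the core of compound 1: pyrrolidin-1-yl in place of diisopropylamino on a thiocarbonyl carbon. Among the compounds with values here, the expected step for compound 4 is a 27-fold lower number from compound 1 to compound 4 (1.42 log units; beyond the scatter), resting on the single measured pair with its step of a 33-fold lower number from compound 2 to compound 3 (1.52 log units; beyond the scatter), so the expectation is held loosely. Compound 4 is thus estimated at 600 nM, with an expected range from 200 nM to 3000 nM.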

Compound 4, half-maximal inhibitory concentration: 8900 nM
For compound 4 the middle estimate is 15-fold (1.17 log units) below the measured one, and the stated range ends below it.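

In this assay, pyrrolidin-1-yl in place of diisopropylamino on a thiocarbonyl carbon gives a 1.8-fold lower number from compound 1 to compound 4 (0.25 log units; within the scatter), so the large step seen on the core of compound 2 does not carry over to the core of compound 1: the same change on two cores in this assay, a 33-fold lower number (1.52 log units; beyond the scatter) from compound 2 to compound 3 and a 1.8-fold lower number (0.25 log units; within the scatter) from compound 1 to compound 4, 19-fold (1.27 log units) apart, beyond the scatter of two such steps. In these two pairs, the effect of this change is therefore not transferable from one core to the other. Two pairs give no rule for any further core, and they do not show which difference between the cores goes with the gap.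

Open, as far as these compounds go, is how a piperidin-1-yl or morpholin-4-yl group on a thiocarbonyl carbon would read on each core. Within the data shown here, also open is whether a compound differing from compound 1 or compound 3 in only one place on the core would separate the two steps.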